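The source may hold more compounds than are shown below. What is called first, only, known or untested is meant among the compounds shown, and "the series" means these compounds.

Compound 2 `O=C(Nc1ccc(Cl)cc1)N[C@H]1CC[C@H](Oc2ccc(F)cc2)CC1` carries a 4-chlorophenyl group on an amide-type nitrogen of the shared core. In a functional assay on CRL2813 cells (Homo sapiens) for cytotoxicity, read by sulforhodamine B assay, with a stated time of 5 days (on this read-out higher numbers stand for weaker inhibition and lower numbers for stronger inhibition), compound 2 gives only a limit, > 20000 nM. The nearest measured comparison is compound 1 `O=C(Nc1cccc([N+](=O)[O-])c1)N[C@H]1CC[C@H](Oc2ccc(F)cc2)CC1`, which bears a 3-nitrophenyl group on that same amide-type nitrogen; in this assay compound 1 gives 6700 nM. That single change gave an at least 2.9-fold higher number from compound 1 to compound 2 (0.47 log units; beyond the scatter), with the weaker compound resting at the limit of > 20000 nM in this assay, at which 1 of the 2 values shown sits.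

Compound 3 `Cc1ccccc1NC(=O)N[C@H]1CC[C@H](Oc2ccc(F)cc2)CC1` has not yet been measured. It differs from compound 2 in one place: 2-methylphenyl in place of 4-chlorophenyl on an amide-type nitrogen. For the measured compounds named here, no measured step tests a 2-methylphenyl group, so nothing on hand says which way this change should move the number. Going by the values given here, the one step known, from compound 1 to compound 2, shows that exchanging the aryl group can shift the value beyond the scatter, but it gives no direction for this particular exchange. The expectation is therefore that compound 3 stays close to where compound 2 stands, and the step is estimated as a number no higher from compound 2 to compound 3 (the limit leaves the size open). Compound 3 is thus estimated at 20000 nM, within a range from 7000 nM to 60000 nM.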

Compound 3, half-maximal inhibitory concentration: > 20000 nM
Compound 3 gave a limit, no number (the forecaster's own chance of this, stated with the estimate: 55%); the middle value sits exactly at the limit.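

In this assay compound 3 gives only a limit, > 20000 nM. Replacing 3-nitrophenyl with 2-methylphenyl on the amide-type nitrogen gives an at least 2.9-fold higher number from compound 1 to compound 3 (0.47 log units; beyond the scatter), so the earlier step with 4-chlorophenyl is no longer the only exchange that moves the number this way; of the three groups shown at this position, only 3-nitrophenyl gives a value that can be read as a number. The step between the two limit compounds cannot be read, and 4-chlorophenyl and 2-methylphenyl therefore cannot be ranked against each other, because the assay stops at a ceiling for both: the limit of > 20000 nM in this assay, at which 2 of the 3 values shown sit.

The compounds shown leave open whether the lower number of compound 1 belongs to the nitro group itself or to where it sits on the ring, since each exchange changes both the substituent and its place. They also leave open how a 4-nitrophenyl or 3-aminophenyl group on the same nitrogen would read, and either could help separate those two possibilities.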